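A few compounds are considered here, and "the series" means these few. Any claim that something is new, unique, unknown or untested is made for them only; others in the source may bear on it.

Three compounds sharing one core were tested in a functional assay on A549 cells (Homo sapiens) for antiproliferative activity, read by MTT assay, with a stated time of 48 h; a higher number here means a weaker inhibitor, a lower number a stronger inhibitor. Compound 1 `COc1ccc2c(/C=C/C(=O)c3cc(OC)c(OC)c(SC)c3)c[nH]c2c1` gives 115 nM, compound 2 `COc1ccc2c(/C=C/C(=O)c3cc(N)c(OC)c(OC)c3)c[nH]c2c1` gives 193 nM and compound 3 `COc1ccc2c(/C=C/C(=O)c3cc(OC)c(OC)c([N+](=O)[O-])c3)c[nH]c2c1` gives 331 nM. Two measured steps reach compound 3. One is a 2.9-fold higher number from compound 1 to compound 3 (0.46 log units; beyond the scatter), which separates it from the methylsulfanyl analogue. The other is a 1.7-fold higher number from compound 2 to compound 3 (0.23 log units; within the scatter), which leaves it level with the amino analogue within the scatter. The remaining step, a 1.7-fold higher number from compound 1 to compound 2 (0.22 log units; within the scatter), also stays within the scatter.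

Compound 4 `COc1cc(C(=O)/C=C/c2c[nH]c3ccccc23)cc([N+](=O)[O-])c1OC` keeps the nitro group of compound 3 and changes elsewhere on the core: hydrogen in place of methoxy on an aromatic carbon. Among the measured compounds shown here, none of the measured steps touches this place. All three exchange methylsulfanyl, amino or nitro on an aromatic carbon, so they show only how far numbers have moved in this small set and give no direction for losing this methoxy. The data therefore support only a tentative expectation of a modest rise, similar in size to a 2.9-fold higher number from compound 1 to compound 3 (0.46 log units; beyond the scatter), the largest step seen here. The expected change is a 2.1-fold higher number from compound 3 to compound 4 (0.33 log units; beyond the scatter). For compound 4 the estimated value is 700 nM, with an expected range of 250 nM to 2500 nM.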

Compound 4, half-maximal inhibitory concentration: 1510 nM
Estimate against measurement, compound 4: 2.2-fold (0.33 log units) below; measured number inside the range.
By their numbers in this assay, from the lowest: compounds 1, 2 and 3 (each within the scatter of the next, the first and the last beyond it); then compound 4.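

In this assay, hydrogen in place of methoxy on an aromatic carbon of the six-membered aromatic ring, part of a fused system of two rings, gives a 4.6-fold higher number from compound 3 to compound 4 (0.66 log units; beyond the scatter) and so supplies the first measured direction for this place, which the exchanges of methylsulfanyl, amino and nitro could not give. This methoxy therefore matters in the presence of the nitro group: its loss moves the number beyond the scatter, whereas two of the three earlier steps stayed within it, the exception being the step from methylsulfanyl to nitro, and compound 4 at 1510 nM now has the highest number of the four. Nothing among the data shown accounts for why the number rises when this methoxy is lost.

As far as these compounds go, this reading rests on a single pair, so it remains open whether the same exchange would move the number as far with methylsulfanyl or amino in place of the nitro group. From the compounds shown here alone, it also remains open how a hydroxyl group, a fluorine atom or an ethoxy group at this place would compare with methoxy and hydrogen.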